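The compounds below may be only part of what the source reports. "The series", "measured", "known", "first", "only" and "open" are said of these compounds alone.

Values in a functional assay on SF-295 cells (Homo sapiens) for inhibition, read by sulforhodamine B assay, with a stated time of 48 h; on this read-out lower numbers stand for stronger inhibition of growth and higher numbers for weaker inhibition of growth:
compound 1 `Cc1ccc(C2=NN(c3ccc(S(C)(=O)=O)cc3)C(=O)CC2)cc1`: 5360 nM
compound 2 `Cc1cc(O)ccc1C1=NN(c2ccc(S(C)(=O)=O)cc2)C(=O)CC1`: 12400 nM
compound 3 `CCc1ccc(C2=NN(c3ccc(S(C)(=O)=O)cc3)C(=O)CC2)cc1`: not yet measured

Compound 2, at 12400 nM, holds the higher of the two numbers in this assay. The next step swaps 4-hydroxy-2-methylphenyl for 4-ethylphenyl on a carbon with a double bond to nitrogen: 4-ethylphenyl in place of 4-hydroxy-2-methylphenyl on a carbon with a double bond to nitrogen. Among the compounds with values here, only one measured step bears on this, the modest 2.3-fold higher number from compound 1 to compound 2 (0.36 log units; beyond the scatter), which brought in the group that now leaves. Within the data shown here, no measured step shows what 4-ethylphenyl does relative to 4-methylphenyl, so that part stays open. A modest step towards a lower number, meaning stronger inhibition of growth, is therefore expected, close in size to the one measured. The expected change is a 2.3-fold lower number from compound 2 to compound 3 (0.35 log units; beyond the scatter). Compound 3 is estimated at 5500 nM, with an expected range of 2700 nM to 11000 nM.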

Compound 3, concentration for total growth inhibition: 8730 nM
Compound 3: the middle estimate sits 1.6-fold (0.20 log units) below what was measured, and the stated range covers the measured number.
By their numbers in this assay, from the lowest: compounds 1, 3 and 2 (each within the scatter of the next, the first and the last beyond it).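

In this assay, the exchange at this position gives a 1.4-fold lower number from compound 2 to compound 3 (0.15 log units; within the scatter) and so does not separate 4-ethylphenyl from 4-hydroxy-2-methylphenyl, although the step from compound 1 to compound 2 lay beyond the scatter. Extending 4-methylphenyl to 4-ethylphenyl, with methyl in place of hydrogen on a saturated chain carbon bound to an aromatic carbon, gives a 1.6-fold higher number from compound 1 to compound 3 (0.21 log units; within the scatter) and separates those two groups no better. This places compound 3 within the scatter of both earlier compounds, and no available measurement accounts for these numbers.

Still open, from the compounds shown here alone, is whether a longer chain, such as propyl, or an amine or a carboxylic acid on the phenyl ring would move the number beyond the scatter. The separate contributions of the hydroxy and methyl groups of 4-hydroxy-2-methylphenyl also remain unresolved, and 4-hydroxyphenyl would be the informative comparison.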